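Swapping the Ring Amine for an Acetamide

This account rests on a few compounds, and the source may have more. Where it says the series, first, only, none or still open, it means among the compounds named here.

Among the compounds with values here, in a functional assay on the whole organism with Rattus norvegicus as the target (on this read-out higher numbers stand for an effect only at larger amounts of compound and lower numbers for an effect already at smaller amounts), compound 2 `COc1cc(N2CCCC2)c(Cl)cc1C(=O)NC1CCN(Cc2ccccc2)C1` gives 0.6 mg/kg, the only plain number in this set. Compound 1 `COc1cc(NCc2ccccc2)c(Cl)cc1C(=O)NC1CCN(Cc2ccccc2)C1` reaches only a limit of the assay, > 30 mg/kg. Between these two lies the single measured step, an at least 50-fold lower number from compound 1 to compound 2 (1.69 log units; beyond the scatter), which shows that the group on this aromatic carbon can move the result a great deal, with the limit of > 30 mg/kg in this assay, at which 1 of the 2 values shown sits, marking the weaker side. Compound 3 `COc1cc(N(C)C(C)=O)c(Cl)cc1C(=O)NC1CCN(Cc2ccccc2)C1` is not yet measured. It differs from compound 2 by acetyl(methyl)amino in place of pyrrolidin-1-yl on an aromatic carbon. Within the data shown here, no measured step covers this exact exchange, so the only guide is that changing the group at this position has already shifted the number strongly once. The expected result is a move toward a higher number, an 8.3-fold higher number from compound 2 to compound 3 (0.92 log units; beyond the scatter), though its size is uncertain. Compound 3 is estimated at 5 mg/kg, with a likely range from 1 mg/kg to 30 mg/kg.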

Compound 3, dose for half-maximal effect: > 30 mg/kg
Compound 3: a limit, no number; the forecaster's own chance of this, stated with the estimate: 35%; at least 6.0-fold (0.77 log units) between middle value and limit.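

In this assay, the exchange on this aromatic carbon gives an at least 50-fold higher number from compound 2 to compound 3 (1.69 log units; beyond the scatter), so a second group, very different from benzylamino, also loses the low number of compound 2. Pyrrolidin-1-yl and acetyl(methyl)amino have equal counts of heavy atoms, hydrogen-bond donors and hydrogen-bond acceptors, so these counts do not separate the two; they differ in that only the first has a ring and only the second has a carbonyl. Compound 1 and compound 3 each carry a limit rather than a number, so the step between them cannot be read: the limit of > 30 mg/kg in this assay, at which 2 of the 3 values shown sit.

The compounds shown leave open whether the low number depends on the ring or on the absence of a carbonyl. A plain dimethylamino group would speak to the first point, and a piperidin-1-yl group would show whether a larger ring is also compatible with a low number.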